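Mirror-image pair in the pyrrolidine acetic acid series

This account rests on a few compounds, and the source may have more. Where it says the series, first, only, none or still open, it means among the compounds named here.

Going by the values given here, compound 2 `COc1ccc(F)c(-c2ccc(Cc3ccc(N4C[C@@H](C(F)(F)F)C[C@H]4CC(=O)O)cc3)c(C)c2)c1` has the highest number of the two measured so far in a functional assay on cells for agonist activity at Free fatty acid receptor 1 (Homo sapiens), read by FLIPR and calcium flux, with a stated time of 100 s; a higher number here means that more compound is needed for the effect, a lower number that less compound is needed: compound 2 gives 490 nM. Its nearest neighbour is compound 1 `COc1ccc(F)c(-c2ccc(Cc3ccc(N4CCC[C@H]4CC(=O)O)cc3)c(C)c2)c1`, which in this assay gives 220 nM; the step of a 2.2-fold higher number from compound 1 to compound 2 (0.35 log units; beyond the scatter) comes with a trifluoromethyl in place of hydrogen on a saturated ring carbon.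

Compound 3 `COc1ccc(F)c(-c2ccc(Cc3ccc(N4C[C@H](C(F)(F)F)C[C@@H]4CC(=O)O)cc3)c(C)c2)c1` is the mirror image of compound 2: the two compounds have the same atoms and bonds and differ only in configuration as drawn: 2 of 2 stereo elements differ (all stereocentres are inverted: mirror images); a stereocentre at a saturated ring carbon is drawn S in compound 2 and R in compound 3; a stereocentre at a saturated ring carbon is drawn S in compound 2 and R in compound 3.

Among the compounds with values here, no measured step bears on this change; the only step known, a 2.2-fold higher number from compound 1 to compound 2 (0.35 log units; beyond the scatter), concerns a substituent and not configuration, so it gives no guide to size or direction. Mirror images commonly differ in this assay by more than the scatter, in either direction, and the data here cannot say which. Compound 3 is therefore expected to fall around 1500 nM, with a wide range from 250 nM to 9000 nM; the expected step of a 3.1-fold higher number from compound 2 to compound 3 (0.49 log units; beyond the scatter) is uncertain in direction.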

Compound 3, half-maximal effective concentration: 110 nM
Compound 3: the middle estimate sits 14-fold (1.13 log units) above what was measured, outside the stated range (below it).
By their numbers in this assay, from the lowest: compounds 3 and 1 (each within the scatter of the next); then compound 2.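

In this assay the inversion of both stereocentres gives a 4.5-fold lower number from compound 2 to compound 3 (0.65 log units; beyond the scatter), so this series responds to configuration at these saturated ring carbons, and the form drawn R at both needs less compound than the form drawn S at both. The gap can be assigned to configuration alone because nothing else separates the pair: the fact that compounds 2 and 3 differ only in the configuration as drawn. The earlier trifluoromethyl step, a 2.2-fold higher number from compound 1 to compound 2 (0.35 log units; beyond the scatter), therefore describes one configuration only and cannot stand as the effect of that group in general.

On these data alone, both stereocentres change together here, so the share of each in the gap stays open, and a pair with only one centre inverted would be needed to separate them. Also open, as far as these compounds go, is whether a methyl or a hydroxyl on the same ring carbon would show the same preference between mirror images.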